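A few compounds are considered here, and "the series" means these few. Any claim that something is new, unique, unknown or untested is made for them only; others in the source may bear on it.

- Compound 1 `NC(=O)c1ccc(-c2cnc(N)c(-c3ccc(C(F)(F)F)cc3)n2)cc1`: 80000 nM
- Compound 2 `Nc1ncc(-c2ccc(C(=O)N3CCC(N)CC3)cc2)nc1-c1ccc(C(F)(F)F)cc1`: 200000 nM
- Compound 3 `Nc1ncc(-c2ccc(C(=O)O)cc2)nc1-c1ccc(C(F)(F)F)cc1`: < 5000 nM

These values come from a physicochemical assay for solubility, read by HPLC, using the shake flask method, with a stated time of 2 h, at pH 2; a lower number here means a less soluble compound, a higher number a more soluble compound. Compound 3 stands at < 5000 nM, which is a limit of the assay and not a number. Compound 4 `COC(=O)c1ccc(-c2cnc(N)c(-c3ccc(C(F)(F)F)cc3)n2)cc1` differs from it by methyl in place of hydrogen on an oxygen next to a carbonyl group. Among the compounds with values here, two measured steps bear on this carbonyl position: an at least 16-fold lower number from compound 1 to compound 3 (1.20 log units; beyond the scatter) and an at least 40-fold lower number from compound 2 to compound 3 (1.60 log units; beyond the scatter). Both are large, but neither makes this exact change, so only a modest rise in this assay is expected. The expected change is an at least 1.6-fold higher number from compound 3 to compound 4 (0.20 log units; that floor lies within the scatter). For compound 4 the estimated value is 8000 nM, with an expected range from 3000 nM to 30000 nM.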

Compound 4, solubility: < 5000 nM
Compound 4 was reported as a limit (the forecaster's own chance of this, stated with the estimate: 40%); at least 1.6-fold (0.20 log units) between middle value and limit.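

In this assay, methoxy on the carbonyl carbon gives an at least 16-fold lower number from compound 1 to compound 4 (1.20 log units; beyond the scatter) and an at least 40-fold lower number from compound 2 to compound 4 (1.60 log units; beyond the scatter), so a low reading at this carbonyl is no longer seen with hydroxy alone. Compound 4 stands at < 5000 nM, a limit of the assay and not a number. Compound 3 and compound 4 both rest on limits, so the step between them cannot be read and methyl in place of hydrogen on this oxygen gets no size: the limit of < 5000 nM in this assay, at which 2 of the 4 values shown sit.

As far as these compounds go, it remains open how far under that limit either compound lies. From the compounds shown here alone, it is also open whether a longer chain on this oxygen, or an amine other than 4-aminopiperidin-1-yl on the carbonyl carbon, would give a readable value.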